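A few compounds are considered here, and "the series" means these few. Any claim that something is new, unique, unknown or untested is made for them only; others in the source may bear on it.

The account concerns solubility as read in a physicochemical assay for solubility, at pH 6.8; on this read-out lower numbers stand for lower solubility and higher numbers for higher solubility. Of the compounds shown here, three have been measured so far. Compound 1 `Cc1ccc(C(=O)Nc2cn3ncnc3c(O[C@H]3CCN(C(=O)CC(C(F)(F)F)C(F)(F)F)[C@@H](C)C3)c2C)cn1` gives 170000 nM in this assay. Compound 2 `Cc1ccc(C(=O)Nc2cn3ncnc3c(CN3CCN(C(=O)C4CCCC4)[C@@H](C)C3)c2C)cn1` gives 190000 nM, the highest of the three numbers shown, though compound 1 stands within the scatter of it, whereas compound 3 `Cc1ccc(C(=O)Nc2cc(F)cc(CN3CCN(C(=O)C4CCCC4)[C@@H](C)C3)c2C)cn1` gives 71000 nM and lies beyond the scatter below it. The step now followed leads from compound 2 to compound 4 `Cc1ccc(C(=O)Nc2cn3ncnc3c(CN3CCN(C(=O)CC(C(F)(F)F)C(F)(F)F)[C@@H](C)C3)c2C)cn1`, which has not yet been measured. The change is 3,3,3-trifluoro-2-(trifluoromethyl)propyl in place of cyclopentyl on a carbonyl carbon. Among the measured compounds shown here, no measured pair carries this same change on its own, so its size is uncertain; compound 1 bears the entering group on another core and gives 170000 nM, close to compound 2. Compound 4 is therefore expected to give 120000 nM, between 50000 nM and 300000 nM. The step of a 1.6-fold lower number from compound 2 to compound 4 (0.20 log units; within the scatter) is expected to be small, downward if anything, and quite possibly within the scatter.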

Compound 4, solubility: 200000 nM
The estimate for compound 4 lay 1.7-fold (0.22 log units) below the measured number, within the range that was stated.
By their numbers in this assay, from the lowest: compound 3; then compounds 1, 2 and 4 (each within the scatter of the next).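

Read on the shared core, this assay shows the change directly, as a 1.1-fold higher number from compound 2 to compound 4 (0.02 log units; within the scatter). At this carbonyl carbon, the read-out therefore does not separate 3,3,3-trifluoro-2-(trifluoromethyl)propyl, with 10 heavy atoms, from cyclopentyl, with 5. Nothing shown gives a reason for this result.

From the compounds shown here alone, it remains open whether the same change would also leave the number in place on the core of compound 3, which gives 71000 nM. Also open, going by these compounds, is how an amine or a longer carbon chain on this carbonyl carbon would read.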